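Moving a fluorine on a compound at the assay limit

The source may hold more compounds than are shown below. What is called first, only, known or untested is meant among the compounds shown, and "the series" means these compounds.

Compound 1 (`O=C(Nc1ccc2sc(-c3cccc(F)c3)nc2c1)N1CCCCC1`) is measured in an ADME assay on HepG2 cells (Homo sapiens) for inhibition, read by resazurin assay, with a stated time of 48 h; on this read-out lower numbers stand for an effect already at smaller amounts and higher numbers for an effect only at larger amounts of compound. There compound 1 gives > 50 uM, which is a limit and not a number. Compound 2 (`O=C(Nc1ccc2sc(-c3ccccc3)nc2c1)c1cccs1`) gives > 50 uM, also a limit. Compound 3 (`O=C(Nc1ccc2sc(-c3cccc(F)c3)nc2c1)N1CCCC1`) gives > 50 uM, again a limit. The whole set so far is therefore (the limit of > 50 uM in this assay, at which 3 of the 3 values shown sit), so compound 1 has no number to rank it by.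

Compound 4 (`O=C(Nc1ccc2sc(-c3ccccc3F)nc2c1)N1CCCCC1`) has 2-fluorophenyl in place of 3-fluorophenyl on an aromatic carbon. Among the compounds with values here, the one measured step, a step that the two limits leave unreadable from compound 1 to compound 3, has pyrrolidin-1-yl in place of piperidin-1-yl on a carbonyl carbon. It changes a different place and gives no size to carry over. Nothing measured therefore points to a change in either direction in this assay, and none beyond the scatter is expected. The estimated step is a step that the limit leaves unreadable from compound 1 to compound 4. For compound 4 the estimate is 60 uM, with an expected range from 30 uM to 100 uM, and the assay will most likely report only a limit again.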

Compound 4, concentration for 90% of the maximal effect: > 50 uM
Compound 4 ended at the assay's limit; the forecaster's own chance of this, stated with the estimate: 85%; the middle value does not contradict the limit.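

Compound 1 and compound 4 both give only a limit in this assay, so the step between them cannot be read, and 2-fluorophenyl in place of 3-fluorophenyl gets no size. The compounds shown leave open which change, if any, would give a real number, as all share one limit: the limit of > 50 uM in this assay, at which 4 of the 4 values shown sit.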